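A few compounds are considered here, and "the series" means these few. Any claim that something is new, unique, unknown or untested is made for them only; others in the source may bear on it.

Measured compounds: compound 1 `CN1CCN(c2ccc(Nc3ncc4nc(Nc5ccc(F)cc5)n([C@@H]5CCN(C(=O)CO)C5)c4n3)cc2)CC1` at 350 nM in a functional assay on HCC827 cells (Homo sapiens) for antiproliferative activity, read by MTT assay, with a stated time of 72 h (on this read-out lower numbers stand for stronger inhibition and higher numbers for weaker inhibition), and compound 2 `CN1CCN(c2ccc(Nc3ncc4nc(Nc5ccc(F)cc5)n([C@H]5CCCN(S(=O)(=O)C6CC6)C5)c4n3)cc2)CC1` at 8.6 nM in this assay.

Compound 1 holds the highest number of the two. The change to compound 3 `CN1CCN(c2ccc(Nc3ncc4nc(Nc5ccc(F)cc5)n([C@H]5CCCNC5)c4n3)cc2)CC1` is piperidin-3-yl in place of 1-((hydroxymethyl)carbonyl)pyrrolidin-3-yl on an aromatic nitrogen. For the measured compounds named here, only one measured step touches this position: a 41-fold lower number from compound 1 to compound 2 (1.61 log units; beyond the scatter), which swaps both ring size and the group on the ring nitrogen, while compound 3 carries the piperidine with a free ring nitrogen. A smaller move in the same direction is therefore expected, a 2.9-fold lower number from compound 1 to compound 3 (0.46 log units; beyond the scatter). How much of that step comes from the ring alone has not been measured. Compound 3 is estimated at 120 nM, with a range of 25 nM to 600 nM.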

Compound 3, half-maximal inhibitory concentration: 38 nM
Beside the measured number, compound 3's estimate is 3.2-fold (0.50 log units) above it; measured number inside the range.
By their numbers in this assay, from the lowest: compound 2; then compound 3; then compound 1.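

Opening the ring nitrogen and moving to piperidin-3-yl already accounts for a real part of the gain over the 1-((hydroxymethyl)carbonyl)pyrrolidin-3-yl group (a 9.2-fold lower number from compound 1 to compound 3 (0.96 log units; beyond the scatter)). The cyclopropylsulfonyl group still counts on this piperidine, as its replacement by hydrogen gives a step beyond the scatter (a 4.4-fold higher number from compound 2 to compound 3 (0.65 log units; beyond the scatter)). Nothing available here explains either step.

The contributions of ring size and of the group on the ring nitrogen remain unseparated in the step from the pyrrolidine. Going by these compounds, it also remains open how a piperidine nitrogen bearing an acetyl or methanesulfonyl group would compare.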